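This account rests on a few compounds, and the source may have more. Where it says the series, first, only, none or still open, it means among the compounds named here.

Compound 1 `CC[C@H]1CN(c2ncc(C(N)=O)nc2Cl)CCN1C1CCN(C(=O)c2ccc(Cl)nc2N)CC1` and compound 2 `CC[C@H]1CN(c2ncc(C(=O)NC3CC3)nc2Cl)CCN1C1CCN(C(=O)c2ccc(Cl)nc2N)CC1` share one core and differ only on an amide-type nitrogen. In an in vitro assay on BaF3 cells for displacement of a labelled ligand from C-X-C chemokine receptor type 3 (Homo sapiens) (a lower number here means a stronger inhibitor, a higher number a weaker inhibitor), compound 1 gives 2.5 nM, and compound 2 gives 1.2 nM. Among the measured compounds shown here, of the two numbers measured so far, compound 2 has the lowest, and the one step known, a 2.1-fold lower number from compound 1 to compound 2 (0.32 log units; beyond the scatter), places it there.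

Compound 3 `CC[C@H]1CN(c2ncc(C(=O)NC(C)C)nc2Cl)CCN1C1CCN(C(=O)c2ccc(Cl)nc2N)CC1` carries the next change at the same nitrogen: isopropyl in place of cyclopropyl on an amide-type nitrogen. For the measured compounds named here, no measured step in this assay covers a swap of one three-carbon group for another; the only step recorded, from compound 1 to compound 2, concerns the arrival of the cyclopropyl group, not its replacement. That step was modest, and a like-for-like exchange of equally sized groups at the same place gives no reason to expect more than a small shift. The estimated step of a 1.3-fold higher number from compound 2 to compound 3 (0.12 log units; within the scatter) is therefore expected to sit within the scatter. Compound 3 is estimated at 1.6 nM in this assay, with a range from 0.7 nM to 3.6 nM.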

Compound 3, half-maximal inhibitory concentration: 0.9 nM
The estimate for compound 3 lay 1.8-fold (0.25 log units) above the measured number; the range from low to high includes it.
By their numbers in this assay, from the lowest: compounds 3 and 2 (each within the scatter of the next); then compound 1.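

In this assay, replacing the three-membered ring of cyclopropyl with the ringless isopropyl gives a 1.3-fold lower number from compound 2 to compound 3 (0.12 log units; within the scatter), so at this amide-type nitrogen the two groups, each of 3 carbon atoms, cannot be told apart and the ring is not required to reach this level. Isopropyl also gives a 2.8-fold lower number from compound 1 to compound 3 (0.44 log units; beyond the scatter), so the modest step away from the amide hydrogen now appears with two different groups rather than one. Nothing shown here explains why the two groups give matching numbers or why either differs from the hydrogen.

These two small carbon groups leave open how much room this nitrogen tolerates: a longer chain such as n-butyl, or a group carrying other atoms such as a hydroxyethyl chain or a carboxylic acid, could give a very different number. Because the rest of the shared core stays fixed in all the compounds shown, it also remains open whether isopropyl and cyclopropyl would still match if another part of the molecule were changed.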